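The source may hold more compounds than are shown below. What is called first, only, known or untested is meant among the compounds shown, and "the series" means these compounds.

Measured compounds:
- compound 1, `CCCCCCCCN(C)C(=O)Cn1cc(Cc2cnc(=O)n(C)c2)c(=O)nc1SCc1ccc(F)cc1`: 19%
- compound 2, `CCCCCCCCCCCCN(C)C(=O)Cn1cc(Cc2cnc(=O)n(C)c2)c(=O)nc1SCc1ccc(F)cc1`: 32%
- compound 3, `CCCCCCCCCCCCN(C)C(=O)Cn1cc(Cc2cnc(=O)n(CCO)c2)c(=O)nc1SCc1ccc(F)cc1`: 36%

All three were tested in a functional assay on a cell-free system (plasma, Oryctolagus cuniculus) for inhibition of platelet-activating factor acetylhydrolase (Homo sapiens), tested at 100 nM; a higher number here means more inhibition at the concentration tested (going by the name of the read-out), a lower number less inhibition. Compound 1 gives the lowest of the three numbers; compound 2 is nearest, by a number 13 percentage points higher from compound 1 to compound 2 (beyond the scatter), and compound 3 lies furthest from it.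

Compound 4, `CCCCCCCCN(C)C(=O)Cn1cc(Cc2cnc(=O)n(CC(=O)NC)c2)c(=O)nc1SCc1ccc(F)cc1`, has not yet been measured in this assay. It differs from compound 1 in one place: methylcarbamoyl in place of hydrogen on a saturated chain carbon bound to an aromatic nitrogen.

Within the data shown here, only one measured step bears on this place. Going from compound 2 to compound 3, a hydroxymethyl group was added on the same saturated chain carbon bound to an aromatic nitrogen, and the read-out moved only by a number 4 percentage points higher from compound 2 to compound 3 (within the scatter), a change inside the usual scatter. The step from compound 1 to compound 2 concerns a different part of the molecule, the long chain, and says nothing about this spot. So for compound 4 the expectation is a step of about a number 3 percentage points higher from compound 1 to compound 4 (within the scatter), that is, nothing beyond the scatter. Compound 4 is therefore estimated to give 22% in this assay, with a likely range from 10% to 35%.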

Compound 4, a percentage reported as inhibition, at one concentration (the size of the read-out at that concentration, not a potency): 42%
Compound 4: the middle estimate sits 20 percentage points below what was measured; measured number outside the range, above it.
By their numbers in this assay, from the lowest: compound 1; then compounds 2, 3 and 4 (each within the scatter of the next).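

In this assay, methylcarbamoyl on a saturated chain carbon bound to an aromatic nitrogen gives a number 23 percentage points higher from compound 1 to compound 4 (beyond the scatter), so this place can move the read-out beyond the scatter. Hydroxymethyl on the same carbon gave only a number 4 percentage points higher from compound 2 to compound 3 (within the scatter), but that step was taken with the longer chain of compound 2, so it cannot be said whether the two steps differ through the group added or through that chain. Nothing measured here accounts for the rise seen with compound 4.

Going by these compounds, it remains open whether methylcarbamoyl would add as much on the longer chain of compound 2. On these data alone, it is also open how a carboxylic acid, an amine or a dimethylcarbamoyl group would read at this same carbon, which would show which part of the added group matters.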